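Replacing the silicon group on a shared core

This account rests on a few compounds, and the source may have more. Where it says the series, first, only, none or still open, it means among the compounds named here.

In a functional assay on MCF7 cells (Homo sapiens) for antiproliferative activity, read by MTT assay, with a stated time of 48 h (on this read-out lower numbers stand for stronger inhibition and higher numbers for weaker inhibition), compound 1 `CC(C)=CCC[C@]1(C)/C=C/[C@@H](OC(=O)C=C(C)C)[C@](C)(O)/C=C/C(=O)/C(CCl)=C\C1` gives 610 nM and compound 2 `CC(C)=CCC[C@]1(C)/C=C/[C@@H](OC(=O)C=C(C)C)[C@](C)(O)/C=C/C(=O)/C(CN2CCN(C)CC2)=C\C1` gives 550 nM. Their swap of groups yields a 1.1-fold lower number from compound 1 to compound 2 (0.04 log units; within the scatter). Compound 3 `CC(C)=CCC[C@]1(C)/C=C/[C@@H](OC(=O)C=C(C)C)[C@](C)(O)/C=C/C(=O)/C(C[Si](C)(C)C(C)(C)C)=C\C1` is the weakest of the three, at 6040 nM. The steps leading to it are a 9.9-fold higher number from compound 1 to compound 3 (1.00 log units; beyond the scatter) and an 11-fold higher number from compound 2 to compound 3 (1.04 log units; beyond the scatter).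

Compound 4 `CC(C)=CCC[C@]1(C)/C=C/[C@@H](OC(=O)C=C(C)C)[C@](C)(O)/C=C/C(=O)/C(COC(=O)c2ccc([N+](=O)[O-])cc2)=C\C1` differs from compound 3 by a group of 12 heavy atoms (7 carbon, 1 nitrogen, 4 oxygen; one six-membered aromatic ring of carbon only) in place of a group of 7 heavy atoms (6 carbon, 1 silicon; no ring), on a saturated chain carbon bound to a double-bonded ring carbon. Among the measured compounds shown here, only the silicon-bearing group has given a high number so far, yet the incoming group resembles neither the chloro of compound 1 nor the 4-methylpiperazin-1-yl of compound 2. A partial return towards their values is therefore expected, with the size of those steps only partly regained. The expected change is a 5.0-fold lower number from compound 3 to compound 4 (0.70 log units; beyond the scatter). For compound 4 the estimated value is 1200 nM, within an expected range of 350 nM to 4500 nM.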

Compound 4, half-maximal inhibitory concentration: 670 nM
For compound 4 the middle estimate is 1.8-fold (0.25 log units) above the measured one, within the range that was stated.
By their numbers in this assay, from the lowest: compounds 2, 1 and 4 (each within the scatter of the next); then compound 3.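

Swapping the silicon-bearing group for ((4-nitrophenyl)carbonyl)oxy gives a 9.0-fold lower number from compound 3 to compound 4 (0.95 log units; beyond the scatter) in this assay and brings the number back into line with the other two compounds. The new group shows a 1.1-fold higher number from compound 1 to compound 4 (0.04 log units; within the scatter) and a 1.2-fold higher number from compound 2 to compound 4 (0.09 log units; within the scatter) so three quite unlike groups, one with an aromatic ring, give matching numbers on this saturated chain carbon, and only compound 3 goes against that pattern. Nothing given here explains why the silicon-bearing group stands apart.

From the compounds shown here alone, whether a carboxylic acid or a free hydroxyl at this place would match compound 1, compound 2 and compound 4 stays open. So does whether a second silicon-bearing group, such as trimethylsilyl, would behave like compound 3.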